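Exchanging an acetamidophenyl ester for a nitrooxymethylphenyl ester

The compounds below may be only part of what the source reports. "The series", "measured", "known", "first", "only" and "open" are said of these compounds alone.

Compound 1 `CC(=O)Oc1ccccc1C(=O)O[C@H]1CO[C@H]2[C@@H]1OC[C@H]2OC(=O)c1cccc(C)c1` gives 0.0203 h in an ADME assay on a cell-free system (plasma, Homo sapiens) for metabolic stability, with Plasma (Rattus norvegicus) as the target, read by HPLC, at pH 7.4; on this read-out higher numbers stand for a longer-lived compound and lower numbers for a shorter-lived compound.
Compound 2 `COc1ccc(C(=O)O[C@@H]2CO[C@H]3[C@@H]2OC[C@@H]3OC(=O)c2ccccc2OC(C)=O)cc1` gives 0.0183 h in this assay.
Compound 3 `CC(=O)Nc1cccc(C(=O)O[C@@H]2CO[C@H]3[C@@H]2OC[C@@H]3OC(=O)c2ccccc2OC(C)=O)c1` gives 0.0583 h in this assay.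

Compound 3 stands highest of the three; its margin over the others is beyond the scatter, while compounds 1 and 2 sit within the scatter of each other, with a 1.1-fold lower number from compound 1 to compound 2 (0.05 log units; within the scatter). Compound 4 `CC(=O)Oc1ccccc1C(=O)O[C@H]1CO[C@H]2[C@@H]1OC[C@H]2OC(=O)c1ccc(CO[N+](=O)[O-])cc1` differs from compound 3 in one place: 4-((nitrooxy)methyl)phenyl in place of 3-acetamidophenyl on a carbonyl carbon. Among the compounds with values here, the steps that bear on this are a 2.9-fold higher number from compound 1 to compound 3 (0.46 log units; beyond the scatter) and a 3.2-fold higher number from compound 2 to compound 3 (0.50 log units; beyond the scatter), both modest gains on bringing in the acetamido group. Taking that group away again suggests a drop of similar size, and no measured step covers the entering group itself. Compound 4 is therefore expected to fall back toward the level of compounds 1 and 2, giving an estimated 2.4-fold lower number from compound 3 to compound 4 (0.39 log units; beyond the scatter) and a value of 0.024 h, within a range of 0.011 h to 0.06 h.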

Compound 4, half-life: 0.04 h
Estimate against measurement, compound 4: 1.7-fold (0.22 log units) below, within the range that was stated.
By their numbers in this assay, from the lowest: compounds 2, 1, 4 and 3 (each within the scatter of the next, the first and the last beyond it).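

In this assay, within the data shown here, the exchange gives a 1.5-fold lower number from compound 3 to compound 4 (0.16 log units; within the scatter) and so the 3-acetamidophenyl group is not the only group on this carbonyl carbon that reaches this level. The new group also gives a 2.2-fold higher number from compound 2 to compound 4 (0.34 log units; beyond the scatter) but only a 2.0-fold higher number from compound 1 to compound 4 (0.29 log units; within the scatter) and so it clearly separates from just one of the two earlier low compounds. With a hydrogen-bond donor gone from this place in compound 4, the donor of compound 3 is not needed to stay within the scatter of compound 3.

Nothing shown explains why these esters differ in lifetime. As far as these compounds go, how an amine or a carboxylic acid on the same phenyl ring would compare remains open.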